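Swapping a Saturated Ring for an Aromatic One

A few compounds are considered here, and "the series" means these few. Any claim that something is new, unique, unknown or untested is made for them only; others in the source may bear on it.

Measured so far in an assay on membranes from Jurkat cells for displacement of a labelled ligand from Sigma non-opioid intracellular receptor 1 (Homo sapiens), read by scintillation counting, with a stated time of 2 h; on this read-out lower numbers stand for stronger inhibition and higher numbers for weaker inhibition:
compound 1, `Cn1nc(CN2CCCC2)nc1-c1ccc(C2(C(F)(F)F)CC2)cc1`, gives 9.9 nM
compound 2, `Cn1nc(CN2CCCC2)nc1-c1ccc(C2CCCCC2)cc1`, gives 20 nM
compound 3, `Cn1nc(CN2CCCC2)nc1-c1cccc(C2(C(F)(F)F)CC2)c1`, gives 32 nM

Of these three numbers, compound 2 has the second highest. Compound 3 lies nearest, and the two values sit within the usual scatter of each other, so nothing separates them. Going by the values given here, compound 1 lies furthest; the one change between them, cyclohexyl in place of 1-(trifluoromethyl)cyclopropyl on an aromatic carbon, brought a 2.0-fold higher number from compound 1 to compound 2 (0.31 log units; beyond the scatter), a modest step beyond the scatter.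

The next compound, compound 4, `Cn1nc(CN2CCCC2)nc1-c1ccc(-c2ccccc2)cc1`, alters the same place once more: phenyl in place of cyclohexyl on an aromatic carbon. Among the compounds with values here, no measured step compares a saturated ring with an aromatic one of the same size; the only step at this position, a 2.0-fold higher number from compound 1 to compound 2 (0.31 log units; beyond the scatter), exchanged two saturated rings of different shape and moved the number only modestly. Ring shape therefore has not so far produced large effects here, and no clear direction can be drawn from the shown compounds. For compound 4 the expectation is a number close to that of compound 2, a step of no change at the digits printed from compound 2 to compound 4 (within the scatter), not beyond the scatter. The estimate for compound 4 in this assay is 20 nM, expected to fall between 7 nM and 60 nM.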

Compound 4, inhibition constant: 90 nM
Compound 4: the middle estimate sits 4.5-fold (0.65 log units) below what was measured, outside the stated range (above it).
By their numbers in this assay, from the lowest: compound 1; then compounds 2 and 3 (each within the scatter of the next); then compound 4.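

In this assay, this position responds to more than the size of the group: phenyl and cyclohexyl have the same count of heavy atoms, yet an aromatic ring in place of a non-aromatic one gave a 4.5-fold higher number from compound 2 to compound 4 (0.65 log units; beyond the scatter). Going by these compounds alone, both saturated groups, 1-(trifluoromethyl)cyclopropyl and cyclohexyl, give lower numbers than phenyl, the only aromatic example here, and the widest gap at this position is a 9.1-fold higher number from compound 1 to compound 4 (0.96 log units; beyond the scatter). Nothing available here bears on why the aromatic ring gives the higher number.

As far as these compounds go, a single aromatic example is a thin basis, so it remains open whether other aromatic groups would behave like phenyl, such as a pyridine ring, which has a nitrogen in a six-membered aromatic ring, or a phenyl ring carrying a methoxy group. Also open, from the compounds shown here alone, is whether the lower numbers extend to other non-aromatic groups, such as cyclopentyl, a piperidine ring or an open hexyl chain.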